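Moving the methoxy on the anilino group of compound 3

This account rests on a few compounds, and the source may have more. Where it says the series, first, only, none or still open, it means among the compounds named here.

In a functional assay on MDA-MB-231 cells (Homo sapiens) for cytotoxicity, read by MTT assay, with a stated time of 48 h (a higher number here means a weaker inhibitor, a lower number a stronger inhibitor), compound 1 `Fc1ccc2nc(-c3ccccc3)nc(Nc3ccccc3)c2c1` returns only a limit of the assay, > 50000 nM. Compound 2 `Fc1cccc(-c2nc(Nc3ccccc3)c3cc(F)ccc3n2)c1` gives 47800 nM, and compound 3 `COc1ccc(Nc2nc(-c3cccc(F)c3)nc3ccc(F)cc23)cc1` gives 47300 nM, so compound 3 sits alongside compound 2, the two within the scatter of each other. The step of an at least 1.0-fold lower number from compound 1 to compound 2 (0.01 log units; that floor lies within the scatter) and the step of a 1.0-fold lower number from compound 2 to compound 3 (0.00 log units; within the scatter) both stay within the scatter. Compound 4 `COc1ccccc1Nc1nc(-c2cccc(F)c2)nc2ccc(F)cc12` differs from compound 3 by 2-methoxyphenyl in place of 4-methoxyphenyl on a nitrogen on an aromatic ring. Among the compounds with values here, neither measured step touches the methoxyphenyl on that nitrogen, so no step bears on it directly, yet all three measured numbers lie near the same weak level. Compound 4 is therefore expected to give about 50000 nM, between 20000 nM and 120000 nM. The expected step is a 1.1-fold higher number from compound 3 to compound 4 (0.02 log units; within the scatter), within the scatter.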

Compound 4, half-maximal inhibitory concentration: > 50000 nM
Compound 4: only a limit was reported; the forecaster's own chance of this, stated with the estimate: 50%; the middle value sits exactly at the limit.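

In this assay compound 4 returns only a limit of the assay, > 50000 nM. The step of an at least 1.0-fold higher number from compound 3 to compound 4 (0.02 log units; that floor lies within the scatter) and the step of an at least 1.0-fold higher number from compound 2 to compound 4 (0.01 log units; that floor lies within the scatter) are floors only, so 2-methoxyphenyl on this nitrogen shows no stronger number than 4-methoxyphenyl, and how far compound 4 lies past the limit cannot be read. Compound 4 now joins compound 1 at that ceiling: the limit of > 50000 nM in this assay, at which 2 of the 4 values shown sit.

As far as these compounds go, what stays open is whether an amine or a carboxylic acid on this phenyl ring, or a longer chain in place of the methoxy, would give a number clear of that limit.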